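Adding tert-butyl to compound 1: expected step

The compounds below may be only part of what the source reports. "The series", "measured", "known", "first", "only" and "open" are said of these compounds alone.

Of the compounds shown here, three have numbers so far. Compound 1 (`COc1ccc2nc(C)cc(NCc3ccccc3)c2c1`) gives 28600 nM in a functional assay on MCF-10A cells (Homo sapiens) for antiproliferative activity, with a stated time of 48 h (a higher number here means that more compound is needed for the effect, a lower number that less compound is needed), and compound 3 (`COc1ccc2nc(C)cc(SCc3ccccc3)c2c1`) gives 37100 nM there, while compound 2 (`COc1ccc2nc(C)cc(NCc3ccncc3)c2c1`) gives 41600 nM in the same read-out. Compound 1 thus sits with the other two inside the scatter, and none of the three stands apart.

Compound 4 (`COc1ccc2nc(C)cc(NCc3ccc(C(C)(C)C)cc3)c2c1`) keeps all of compound 1 apart from one site. The change is tert-butyl in place of hydrogen on an aromatic carbon, para to a large group (tert-butyl in place of hydrogen on an aromatic carbon).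

Among the measured compounds shown here, only one measured step concerns the same ring. The exchange of phenyl for pyridin-4-yl gave a 1.5-fold higher number from compound 1 to compound 2 (0.16 log units; within the scatter) and so stayed within the scatter. For the measured compounds named here, that step swaps the ring rather than adding to it, and no measured compound carries an added group there, so the evidence is thin. No shift beyond the scatter is expected in this assay in either direction, and the range is kept wide for that reason. The estimated step is a 1.1-fold lower number from compound 1 to compound 4 (0.06 log units; within the scatter) and nothing larger is expected. For compound 4 the estimated value is 25000 nM with an expected range from 9000 nM to 60000 nM in this read-out.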

Compound 4, half-maximal effective concentration: 7000 nM
Compound 4: middle estimate off by 3.6-fold (0.55 log units), on the high side; measured number below the stated range.
By their numbers in this assay, from the lowest: compound 4; then compounds 1, 3 and 2 (each within the scatter of the next).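

Tert-butyl in place of hydrogen on an aromatic carbon, para to a large group, gives a 4.1-fold lower number from compound 1 to compound 4 (0.61 log units; beyond the scatter) in this assay, the first step in the series to lie beyond the scatter. The only earlier step on this ring, the exchange of phenyl for pyridin-4-yl, gives a 1.5-fold higher number from compound 1 to compound 2 (0.16 log units; within the scatter) and stays within the scatter, so the ring had shown no clear response until a group was added to it; this position accepts an added group of 4 carbon atoms, and the number falls rather than rises. No measured property or other evidence on these compounds bears on why the number falls.

On these data alone, it remains open whether the shift is specific to tert-butyl or follows from any substituent at this carbon, a question that a methyl group, a methoxy group or a carboxylic acid at the same place would help to settle. As far as these compounds go, it is also open whether the same addition gives a comparable step on compound 2 or compound 3, so the result is tied for now to the core and the nitrogen link of compound 1.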